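This account rests on a few compounds, and the source may have more. Where it says the series, first, only, none or still open, it means among the compounds named here.

Measured compounds:
compound 1, `CCCCCCC(=O)OCc1ccc2oc(=O)c(C(=O)Oc3cccc(Br)c3)cc2c1`, 55.6%;
compound 2, `O=C(Oc1cccc(F)c1)c1cc2cc([N+](=O)[O-])ccc2oc1=O`, 53.6%.

Of the compounds shown here, two have been measured in a functional assay on HT-1080 cells (Homo sapiens), read by transwell migration, with a stated time of 24 h, tested at 1 uM; on this read-out lower numbers stand for a stronger effect and higher numbers for a weaker effect at the one concentration tested. Compound 1 gives 55.6% in this assay, and compound 2 gives 53.6%. The two numbers lie within the usual scatter of repeated measurements of each other, so neither compound can be called stronger or weaker than the other on this read-out; the two compounds also differ in several places at once, so nothing can be drawn from their pair about any single change.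

The account now turns to compound 3, `O=C(Oc1cccc(Br)c1)c1cc2cc([N+](=O)[O-])ccc2oc1=O`, which has not yet been measured in this assay. It differs from compound 2 in one place: bromo in place of fluoro on an aromatic carbon. Among the measured compounds shown here, no measured pair shows the size of such a step, so there is no basis in the numbers for expecting a move beyond the scatter in either direction. Compound 3 is therefore expected to come out close to compound 2, with a step of a number 3.6 percentage points lower from compound 2 to compound 3 (within the scatter). The estimate for compound 3 in this assay is 50%, within a range from 35% to 65%.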

Compound 3, a percentage reported as activity, at one concentration (the size of the read-out at that concentration, not a potency): 35.2%
Estimate against measurement, compound 3: 14.8 percentage points above, within the range that was stated.
By their numbers in this assay, from the lowest: compound 3; then compounds 2 and 1 (each within the scatter of the next).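

In this assay the exchange of 3-fluorophenyl for 3-bromophenyl gives a number 18.4 percentage points lower from compound 2 to compound 3 (beyond the scatter) and so puts the first measured size on a change at this aromatic carbon, showing that the choice of halogen there can move the number beyond the scatter. With the 3-bromophenyl group held fixed, nitro in place of ((hexylcarbonyl)oxy)methyl gives a number 20.4 percentage points lower from compound 1 to compound 3 (beyond the scatter) as a second step, which shows that the other end of the molecule also matters on this read-out, although compounds 1 and 2 could not show this when set against each other. Both steps run towards the lower number, and compound 3 therefore stands lowest of the three, beyond the scatter from each of the others.

Going by these compounds, whether chloro or iodo on the same carbon, an amine in place of the nitro, or a shorter chain in place of the hexyl chain would continue these trends remains open, as does whether the gain from bromo holds when the ((hexylcarbonyl)oxy)methyl group is present. No measurement accompanying these numbers speaks to what lies behind either step.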